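Swapping a methoxy for a chloro on the aryl ring

This account rests on a few compounds, and the source may have more. Where it says the series, first, only, none or still open, it means among the compounds named here.

Of the compounds shown here, two built on a shared core have been tested in an ADME assay on Vero cells (Chlorocebus sabaeus) for cytotoxicity, read by neutral red uptake, tested at 1575 ug/mL; a lower number here means a stronger effect, a higher number a weaker effect of the compound at the concentration tested. Compound 1 `O=C1CSC(c2ccc([N+](=O)[O-])cc2)N1CCN1CCCCC1` gives 15%, and compound 2 `COc1ccccc1C1SCC(=O)N1CCN1CCCCC1` gives 17%. These two numbers lie within the scatter of each other, so compound 2 cannot be set apart from compound 1. Compound 3 `O=C1CSC(c2ccccc2Cl)N1CCN1CCCCC1` is the next compound to be measured; it differs from compound 2 as follows: chloro in place of methoxy on an aromatic carbon. Among the measured compounds shown here, no measured pair shows what such a change does here, so no step beyond the scatter is expected in this assay. Compound 3 is estimated to give 16%, between 6% and 28%, an expected step of a number 1 percentage points lower from compound 2 to compound 3 (within the scatter).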

Compound 3, a percentage reported as activity, at one concentration (the size of the read-out at that concentration, not a potency): 16%
Compound 3: the middle estimate sits on the measured number at the digits printed; the measured number falls inside the stated range.
By their numbers in this assay, from the lowest: compounds 1, 3 and 2 (each within the scatter of the next).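

In this assay, putting chloro in place of methoxy on this aromatic carbon, ortho to a large group, comes to a number 1 percentage points lower from compound 2 to compound 3 (within the scatter). Among the compounds shown here, this is the first direct look at a swap at this position, and it leaves chloro and methoxy indistinguishable in this read-out. No measurement offers an explanation for this result.

From the compounds shown here alone, whether an amine, a carboxylic acid or a longer chain on this aromatic carbon would give a step beyond the scatter remains open. So does whether chloro would behave alike elsewhere on the ring.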